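Methylsulfanyl for Methoxy on the Core of Compound 2

A few compounds are considered here, and "the series" means these few. Any claim that something is new, unique, unknown or untested is made for them only; others in the source may bear on it.

Compound 2 `COc1ncnc2c1c(-c1ccoc1)cn2[C@@H]1O[C@H](CO)[C@@H](O)[C@H]1O` is assessed in a functional assay on HepG2 cells (Homo sapiens) for antiproliferative activity, read by XTT assay, with a stated time of 72 h (a higher number here means a weaker inhibitor, a lower number a stronger inhibitor), where compound 2 gives 290 nM, the lowest of the two numbers shown. Compound 1 `COc1ncnc2c1c(-c1ccsc1)cn2[C@@H]1O[C@H](CO)[C@@H](O)[C@H]1O` gives 430 nM, and the step of a 1.5-fold lower number from compound 1 to compound 2 (0.17 log units; within the scatter) lies within the scatter. Compound 3 `COc1nc(N)nc2c1c(-c1ccoc1)cn2[C@@H]1O[C@H](CO)[C@@H](O)[C@H]1O` gives only a limit of the assay, > 20000 nM. The step of an at least 68-fold higher number from compound 2 to compound 3 (1.83 log units; beyond the scatter) is large. Compound 4 `CSc1ncnc2c1c(-c1ccoc1)cn2[C@@H]1O[C@H](CO)[C@@H](O)[C@H]1O` differs from compound 2 by methylsulfanyl in place of methoxy on an aromatic carbon. Among the measured compounds shown here, no measured step exchanges one of these two groups, so neither step bears directly on it; the change is small in size and keeps the acceptor count, so no step beyond the scatter is expected. Compound 4 is estimated at 250 nM, between 80 nM and 800 nM, which means an expected step of a 1.2-fold lower number from compound 2 to compound 4 (0.06 log units; within the scatter).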

Compound 4, half-maximal inhibitory concentration: > 15000 nM
Compound 4 gave a limit, no number; the forecaster's own chance of this, stated with the estimate: 10%; middle value at least 60-fold (1.77 log units) away from the limit.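

In this assay, compound 4 stands only as a limit of the assay: the limit of > 15000 nM in this assay, at which 1 of the 4 values shown sits.

Methylsulfanyl in place of methoxy on this aromatic carbon, next to the ring nitrogen, gives an at least 51-fold higher number from compound 2 to compound 4 (1.71 log units; beyond the scatter), so a change this small on the core is not silent. The same exchange of sulfur and oxygen between thiophen-3-yl and furan-3-yl gave only a 1.5-fold lower number from compound 1 to compound 2 (0.17 log units; within the scatter), so the two sites do not respond alike.

The compounds shown leave open whether ethoxy, a hydroxyl or an amine on this carbon would keep the activity of compound 2.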